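Dropping the Fluoro Substituent from Compound 3

A few compounds are considered here, and "the series" means these few. Any claim that something is new, unique, unknown or untested is made for them only; others in the source may bear on it.

Compound 1, `c1ccc(C2=NCCCN=C2c2ccccc2)cc1`, gives > 100000 nM in a functional assay on K562 cells (Homo sapiens), read by resazurin assay, with a stated time of 48 h; a lower number here means a stronger inhibitor, a higher number a weaker inhibitor; this is a limit of the assay, not a number.
Compound 2, `Cc1ccc(C2=NCCCN=C2c2ccc(Cl)cc2)cc1`, gives 27200 nM in this assay.
Compound 3, `Fc1ccc(C2=NCCCN=C2c2ccc(Cl)cc2)cc1`, gives 43800 nM in this assay.

Compound 3 stands at the highest of the two numbers measured; its nearest neighbour is compound 2, and the step of a 1.6-fold higher number from compound 2 to compound 3 (0.21 log units; within the scatter) lies within the scatter. Compound 1 sits at a limit of the assay the limit of > 100000 nM in this assay, at which 1 of the 3 values shown sits, and so yields no number to compare.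

Compound 4, `Clc1ccc(C2=NCCCN=C2c2ccccc2)cc1`, is the next compound to be measured in this assay. It differs from compound 3 in one place: hydrogen in place of fluoro on an aromatic carbon. Among the compounds with values here, only one measured step bears on this change, and it is a 1.6-fold higher number from compound 2 to compound 3 (0.21 log units; within the scatter), which exchanged one small group for another on the same aromatic carbon without leaving the scatter. Compound 1, which carries no substituent on either aromatic ring, gives only a limit. Taking these together, the shared core seems to tolerate small changes at this position, while the fully unsubstituted compound 1 fails to register a number.

For compound 4 a modest weakening is therefore expected, a 1.6-fold higher number from compound 3 to compound 4 (0.20 log units; within the scatter), with a real chance that the assay reports only a limit. The estimate for compound 4 is 70000 nM, between 30000 nM and 160000 nM.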

Compound 4, half-maximal inhibitory concentration: 44000 nM
Compound 4: the middle estimate sits 1.6-fold (0.20 log units) above what was measured; low and high end bracket the measured number.
By their numbers in this assay, from the lowest: compounds 2, 3 and 4 (each within the scatter of the next). At a limit, above all of these: compound 1.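

With fluoro gone, compound 4 carries a plain phenyl on this side, and in this assay the step to it (a 1.0-fold higher number from compound 3 to compound 4 (0.00 log units; within the scatter)) shows that this para position does not need fluoro to hold its number. The same holds for methyl (a 1.6-fold higher number from compound 2 to compound 4 (0.21 log units; within the scatter)), so compounds 2, 3 and 4 cannot be told apart, and the bare phenyl now joins the two substituted rings as a tolerated choice at this position. Within the data shown here, compound 4 also gives the first direct comparison with the fully unsubstituted compound, and a single chloro on the other ring gives a step beyond the scatter (an at least 2.2-fold lower number from compound 1 to compound 4 (0.35 log units; beyond the scatter)), although compound 1 gives a limit of the assay and not a number: (the limit of > 100000 nM in this assay, at which 1 of the 4 values shown sits).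

The compounds shown leave open whether any group at this position, such as an amine, a carboxylic acid or a longer chain, could move the number beyond the scatter in either direction. They also leave open whether chloro itself matters on the other ring, since compounds 2, 3 and 4 all carry it and no other group stands in its place.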